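A few compounds are considered here, and "the series" means these few. Any claim that something is new, unique, unknown or untested is made for them only; others in the source may bear on it.

Compound 1 `Cc1cccc(N(C)c2cc(Nc3cccc(C(=O)N(CC(C)C)CC(C)C)c3)ncn2)c1`: 9%
Compound 2 `Cc1cccc(Oc2ccnc(N3CCN(C(=O)c4c(C)noc4C)CC3)n2)c1`: 8%
Compound 3 `CN(CCCn1ccnc1)C(=O)[C@@H]1CCCN1c1nccc(Nc2ccccc2)n1`: 11%

In an assay on isolated protein for inhibition of high affinity nerve growth factor receptor (Homo sapiens), read by HTRF, tested at 10 uM (a lower number here means less inhibition, a higher number more inhibition at the concentration tested (going by the name of the read-out)), all three compounds sit low. Compound 3 has the largest of the three numbers, yet its gaps to compound 1 and compound 2 both lie within the usual scatter, so the three cannot be told apart. Compound 4 `COC[C@@H]1CCCN1C(=O)[C@@H]1CCCN1c1nccc(Nc2ccccc2)n1` keeps the core of compound 3 and changes one group on a carbonyl carbon: 2-(methoxymethyl)pyrrolidin-1-yl in place of (3-(1H-imidazol-1-yl)propyl)(methyl)amino on a carbonyl carbon. Among the compounds with values here, no measured pair shows what such a swap does here. With every measured number at the same low level, the expectation is that compound 4 stays there too, and the step of a number 1 percentage points lower from compound 3 to compound 4 (within the scatter) is expected to be no larger than the scatter. The estimate for compound 4 in this assay is 10%, expected between 0% and 25%.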

Compound 4, a percentage reported as inhibition, at one concentration (the size of the read-out at that concentration, not a potency): 8%
Compound 4: the middle estimate sits 2 percentage points above what was measured, within the range that was stated.
By their numbers in this assay, from the lowest: compounds 2, 4, 1 and 3 (each within the scatter of the next).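

In this assay the swap on the carbonyl carbon gives a number 3 percentage points lower from compound 3 to compound 4 (within the scatter) and so leaves the number at the same low level. Within this one pair, 2-(methoxymethyl)pyrrolidin-1-yl and (3-(1H-imidazol-1-yl)propyl)(methyl)amino cannot be told apart, so the five-membered aromatic ring of the group that leaves is not required to reach this level. Nothing available explains the result. Going by these compounds, what a carboxylic acid or a longer chain ending in an amine would do on this carbonyl carbon stays open. So does whether any change to the shared core would move the number beyond the scatter.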